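Swapping the amine at the chain end of compound 2

This account rests on a few compounds, and the source may have more. Where it says the series, first, only, none or still open, it means among the compounds named here.

Measured compounds in a functional assay on U-937 cells (Homo sapiens) for inhibition, read by MTT assay and WST assay, with a stated time of 72 h, tested at 10 uM; on this read-out higher numbers stand for more inhibition of growth at the one concentration tested and lower numbers for less inhibition of growth:
- compound 1, `CCN1CCN(c2cc(Nc3ccc4sc(C(=O)Nc5c(C)cccc5Cl)cc4c3)nc(C)n2)CC1`: 46.5%
- compound 2, `CCN(CC)CCCOc1cc2ncnc(Nc3ccc4sc(C(=O)Nc5c(C)cccc5Cl)cc4c3)c2cc1OC`: 78%
- compound 3, `Cc1nc(Nc2ccc3sc(C(=O)Nc4c(C)cccc4Cl)cc3c2)cc(N2CCN(C)CC2)n1`: 40.6%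

Among the three measured compounds, compound 2 stands highest in this assay, and its gap to compound 1 as well as to compound 3 lies beyond the scatter. Compound 1 and compound 3 differ only in a number 5.9 percentage points lower from compound 1 to compound 3 (within the scatter), a step within the scatter.

Compound 4, `COc1cc2c(Nc3ccc4sc(C(=O)Nc5c(C)cccc5Cl)cc4c3)ncnc2cc1OCCCN1CCCCC1C`, is not yet measured. It differs from compound 2 by 2-methylpiperidin-1-yl in place of diethylamino on a saturated chain carbon, three bonds along the chain from an oxygen on an aromatic ring. Within the data shown here, no measured pair changes this part of the molecule, so no step bears directly on it. Among the measured compounds shown here, the only measured step, from compound 1 to compound 3, alters a group on an amine nitrogen at the far end of the molecule and stays within the scatter, which offers a loose parallel at best. In the absence of a closer precedent, compound 4 is expected to move by a number 3 percentage points lower from compound 2 to compound 4 (within the scatter), a step not expected to reach beyond the scatter. Compound 4 is therefore estimated at 75% in this assay, within a range from 55% to 92%.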

Compound 4, percent growth inhibition at one concentration: 80.3%
Estimate against measurement, compound 4: 5.3 percentage points below; the measured number falls inside the stated range.
By their numbers in this assay, from the lowest: compounds 3 and 1 (each within the scatter of the next); then compounds 2 and 4 (each within the scatter of the next).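

In this assay the chain end now carries its first measured change, with a number 2.3 percentage points higher from compound 2 to compound 4 (within the scatter) for 2-methylpiperidin-1-yl in place of diethylamino. In this one pair the amine at the end of the 3-carbon propyl chain can therefore be closed into a six-membered non-aromatic ring, with more heavy atoms than diethylamino, and the two compounds still read alike. Nothing at hand gives a reason for this outcome.

The compounds shown leave open what the methyl on the ring contributes, as they offer no comparison with plain piperidin-1-yl, and how a morpholine at the same place would read. They also leave open whether 2-methylpiperidin-1-yl would read the same way on a shorter or a longer chain.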